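Swapping a halogen on the shared core: bromo to fluoro

A few compounds are considered here, and "the series" means these few. Any claim that something is new, unique, unknown or untested is made for them only; others in the source may bear on it.

Measured so far in a physicochemical assay, read by spectrophotometry, with a stated time of 25 min; a higher number here means a weaker inhibitor, a lower number a stronger inhibitor:
- compound 1, `O=c1cc(-c2ccccc2)oc2cc(OCCCCNc3nc4ccccc4s3)cc(O)c12`: 26.5 ug/mL
- compound 2, `O=c1cc(-c2ccccc2)oc2cc(OCCCCNc3nc4ccc([N+](=O)[O-])cc4s3)cc(O)c12`: 30.3 ug/mL
- compound 3, `O=c1cc(-c2ccccc2)oc2cc(OCCCCNc3nc4ccc(Br)cc4s3)cc(O)c12`: 16.1 ug/mL

Compound 3 gives the lowest of the three numbers in this assay, yet its gaps to compound 1 and compound 2 both lie within the scatter, so the three compounds cannot be ranked. Compound 4, `O=c1cc(-c2ccccc2)oc2cc(OCCCCNc3nc4ccc(F)cc4s3)cc(O)c12`, is not yet measured. It differs from compound 3 by fluoro in place of bromo on an aromatic carbon. For the measured compounds named here, the steps that bear on this change are a 1.6-fold lower number from compound 1 to compound 3 (0.22 log units; within the scatter) and a 1.9-fold lower number from compound 2 to compound 3 (0.27 log units; within the scatter), which together show that changing this one position has so far stayed within the scatter. In this assay compound 4 is therefore expected to sit close to compound 3, with a step of a 1.4-fold higher number from compound 3 to compound 4 (0.14 log units; within the scatter). The estimate for compound 4 is 22 ug/mL, expected to fall between 11 ug/mL and 44 ug/mL.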

Compound 4, half-maximal inhibitory concentration: 14.7 ug/mL
The estimate for compound 4 lay 1.5-fold (0.18 log units) above the measured number; low and high end bracket the measured number.
By their numbers in this assay, from the lowest: compounds 4, 3, 1 and 2 (each within the scatter of the next, the first and the last beyond it).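

In this assay, fluoro in place of bromo at this position gives a step that leaves the two halogens indistinguishable (a 1.1-fold lower number from compound 3 to compound 4 (0.04 log units; within the scatter)). This position now shows its first step beyond the scatter, though only a modest one (a 2.1-fold lower number from compound 2 to compound 4 (0.31 log units; beyond the scatter)), while fluoro still cannot be separated from hydrogen (a 1.8-fold lower number from compound 1 to compound 4 (0.26 log units; within the scatter)). No measurement at hand offers a reason for these steps.

As far as these compounds go, whether an amine or a carboxylic acid at this position would move the number clearly away from the halogens remains open.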